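The compounds below may be only part of what the source reports. "The series", "measured", "known", "first", "only" and "open" are said of these compounds alone.

In a functional assay on Ramos cells (Homo sapiens) for antiproliferative activity, read by CCK-8 assay, with a stated time of 72 h (on this read-out lower numbers stand for stronger inhibition and higher numbers for weaker inhibition), compound 1 `C=CC(=O)Nc1cccc(Nc2nc(Nc3ccc(OCC(=O)N4CCCC4C(=O)OC)cc3)ncc2Cl)c1` gives 19700 nM. Going by these compounds, compound 2 `C=CC(=O)Nc1cccc(Nc2nc(Nc3ccc(Cn4cc(C)nc4CC)cc3)ncc2Cl)c1` is recorded only as a limit, < 10900 nM, so its exact position on the scale remains unknown. Compound 3 `C=CC(=O)Nc1cccc(Nc2nc(Nc3ccc(Cn4cc(C)nc4CC)cc3)ncc2F)c1` keeps the structure of compound 2 with one change: fluoro in place of chloro on an aromatic carbon, (fluoro in place of chloro on an aromatic carbon). Among the measured compounds shown here, no measured pair of compounds shows what such an exchange does in this assay, so no change beyond the usual scatter, in either direction, is expected. The expectation rests on compound 2 and its limit of < 10900 nM, which leaves the true starting value open and widens the range. The estimated change is a step that the limit leaves unreadable from compound 2 to compound 3. For compound 3 the expected value is 8000 nM, with an estimated range of 2500 nM to 20000 nM.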

Compound 3, half-maximal inhibitory concentration: < 10900 nM
Compound 3 gave a limit, no number; the forecaster's own chance of this, stated with the estimate: 30%; the middle value lies beyond the limit too.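

Among the compounds shown here, compound 2 and compound 3 are both recorded only as limits and not as numbers, so no step between them can be read: the limit of < 10900 nM in this assay, at which 2 of the 3 values shown sit. The compounds shown leave open where compound 2 and compound 3 truly lie in this assay, and whether fluoro in place of chloro on an aromatic carbon changes the value at all.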